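The source may report more compounds than this note shows. Statements on the series, on what has been measured and on what is new or still open speak of the compounds shown alone.

Three compounds share one core and differ only in the group attached to a carbonyl carbon. In an assay on isolated protein for inhibition of legumain (Mus musculus), read by fluorescence, with stated times of 30 s and 2.5 h (a lower number here means a stronger inhibitor, a higher number a weaker inhibitor), compound 1 `CCOC(=O)/C=C/C(=O)N(CC(N)=O)NC(=O)[C@@H]1CCCN1C(=O)[C@H]1CSCN1C(C)=O` gives 167 nM, compound 2 `CCOC(=O)/C=C/C(=O)N(CC(N)=O)NC(=O)[C@@H]1CCCN1C(=O)C(NC(C)=O)=C(C)C` gives 148 nM, and compound 3 `CCOC(=O)/C=C/C(=O)N(CC(N)=O)NC(=O)[C@@H]1CCCN1C(=O)c1ccc(CNC(C)=O)cc1` gives 267 nM. Compound 3 sits at the top end of these three numbers, yet the steps separating it from the others stay within the scatter: a 1.6-fold higher number from compound 1 to compound 3 (0.20 log units; within the scatter) and a 1.8-fold higher number from compound 2 to compound 3 (0.26 log units; within the scatter). Compound 4 `C#CC[C@H](NC(C)=O)C(=O)N1CCC[C@H]1C(=O)NN(CC(N)=O)C(=O)/C=C/C(=O)OCC` is compound 3 with a group of 8 heavy atoms (6 carbon, 1 nitrogen, 1 oxygen; no ring) in place of a group of 11 heavy atoms (9 carbon, 1 nitrogen, 1 oxygen; one six-membered aromatic ring of carbon only), on a carbonyl carbon. The two steps just named bear on this change, since in each the aromatic group entered rather than left, and both were small. Removing it is therefore expected to give, in this assay, at most a modest drop in the number, not beyond the scatter. Compound 4 is estimated at 160 nM, with a range from 70 nM to 370 nM. The expected step of a 1.7-fold lower number from compound 3 to compound 4 (0.22 log units; within the scatter) would thus stay within the scatter.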

Compound 4, half-maximal inhibitory concentration: 17 nM
For compound 4 the middle estimate is 9.4-fold (0.97 log units) above the measured one; the whole stated range lies above it.
By their numbers in this assay, from the lowest: compound 4; then compounds 2, 1 and 3 (each within the scatter of the next).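

The position on this carbonyl carbon looked flat across compound 1, compound 2 and compound 3, but it can strongly change the number in this assay: the group in compound 4 gives a 16-fold lower number from compound 3 to compound 4 (1.20 log units; beyond the scatter), with an 8.7-fold lower number from compound 2 to compound 4 (0.94 log units; beyond the scatter) and a 9.8-fold lower number from compound 1 to compound 4 (0.99 log units; beyond the scatter). The groups in compound 2 and compound 4 have the same heavy-atom count and no ring, so those two features alone do not account for the gap; only compound 4 has a triple bond. No measurement here explains the gain. As far as these compounds go, whether the triple bond matters remains open: a propyl chain in its place, or a longer chain ending in a triple bond, would test this.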